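Hydroxy in Place of Trifluoromethyl on the Aniline Ring

The source may hold more compounds than are shown below. What is called first, only, known or untested is meant among the compounds shown, and "the series" means these compounds.

Compound 2 `COc1ccc(-c2nn(-c3ccccc3)cc2C(=O)/C=C\Nc2ccc(C(F)(F)F)cc2)cc1` gives in a functional assay on U-87MG ATCC cells (Homo sapiens) for antiproliferative activity, read by MTT assay, with a stated time of 48 h (on this read-out lower numbers stand for stronger inhibition and higher numbers for weaker inhibition), only a limit of the assay, > 50000 nM, and no number. Compound 2 therefore sits at the limit of > 50000 nM in this assay, at which 1 of the 2 values shown sits. Compound 1 `O=C(/C=C\Nc1ccc(O)cc1)c1cn(-c2ccccc2)nc1-c1ccc(Cl)cc1` is measured in this assay at 1500 nM. Compound 3 `COc1ccc(-c2nn(-c3ccccc3)cc2C(=O)/C=C\Nc2ccc(O)cc2)cc1` has not been measured yet; it differs from compound 2 by hydroxy in place of trifluoromethyl on an aromatic carbon. Within the data shown here, no step between two measured compounds is available, so the expected size rests on the structures alone. The step is expected to be an at least 8.3-fold lower number from compound 2 to compound 3 (0.92 log units; beyond the scatter), toward stronger inhibition. For compound 3 the estimate in this assay is 6000 nM, between 1500 nM and 30000 nM.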

Compound 3, half-maximal inhibitory concentration: 3730 nM
Compound 3: middle estimate off by 1.6-fold (0.21 log units), on the high side, within the range that was stated.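

In this assay, exchanging trifluoromethyl for hydroxy moves the series from an assay limit to a measured number (an at least 13-fold lower number from compound 2 to compound 3 (1.12 log units; beyond the scatter)), showing that the group at this position can decide whether a readable value appears at all. Compound 2 gives a limit and not a number, so this step has only a bound: the limit of > 50000 nM in this assay, at which 1 of the 3 values shown sits. With hydroxy held fixed, methoxy in place of chloro gives a modest step (a 2.5-fold higher number from compound 1 to compound 3 (0.40 log units; beyond the scatter)). Going by these compounds, whether an amine or a carboxylic acid at the hydroxy position would do as well remains open, as does whether the gain comes from adding hydroxy or from losing trifluoromethyl.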